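The compounds below may be only part of what the source reports. "The series", "measured", "known", "first", "only" and "open" are said of these compounds alone.

In an in vitro ADME assay on microsomes from liver (Mus musculus) for pharmacokinetics, read by LC-MS, with a stated time of 10 min, tested at 1 uM (a higher number here means faster removal of the compound, a lower number slower removal), compound 1 (`Cc1ccc(NC(=O)[C@H]2CN(C)C[C@@H]2c2ccc(/C=C/C(=O)Nc3ccccc3N)cc2)cn1`) gives 57 mL/min/kg and compound 2 (`CCN1C[C@H](C(=O)Nc2ccc(Cl)cc2)[C@@H](c2ccc(/C=C/C(=O)Nc3ccccc3N)cc2)C1`) gives 35 mL/min/kg while compound 3 (`N#CCN1C[C@H](C(=O)Nc2ccc(Cl)cc2)[C@@H](c2ccc(/C=C/C(=O)Nc3ccccc3N)cc2)C1`) gives 51 mL/min/kg on the same scale. Compound 3 therefore sits within the usual scatter of both: compound 1 is its nearest neighbour and compound 2 its furthest, and neither gap is large enough to count as a real difference.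

Compound 4 (`Nc1ccccc1NC(=O)/C=C/c1ccc([C@H]2CN(Cc3ccccc3)C[C@@H]2C(=O)Nc2ccc(Cl)cc2)cc1`) has not been measured yet. It differs from compound 3 in one place (phenyl in place of cyano on a saturated chain carbon bound to an amine nitrogen in a ring), with phenyl in place of cyano on a saturated chain carbon bound to an amine nitrogen in a ring, so that cyanomethyl becomes benzyl.

Going by the values given here, only one measured step touches this place. Putting cyano in place of methyl there gave a 1.5-fold higher number from compound 2 to compound 3 (0.16 log units; within the scatter) and so did not move the number beyond the scatter. Among the compounds with values here, this single step is thin guidance, since no measured compound yet carries phenyl at this place. On that evidence, no shift beyond the scatter is expected in this assay and the expected step is a 1.3-fold higher number from compound 3 to compound 4 (0.11 log units; within the scatter) as a best guess. Compound 4 is estimated at about 65 mL/min/kg (expected range 32 mL/min/kg to 130 mL/min/kg).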

Compound 4, clearance: 81 mL/min/kg
Beside the measured number, compound 4's estimate is 1.2-fold (0.10 log units) below it, within the range that was stated.
By their numbers in this assay, from the lowest: compounds 2, 3, 1 and 4 (each within the scatter of the next, the first and the last beyond it).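

In this assay, the place on a saturated chain carbon bound to an amine nitrogen in a ring now shows its first change beyond the scatter: phenyl in place of methyl gives a 2.3-fold higher number from compound 2 to compound 4 (0.36 log units; beyond the scatter), though the change is only modest. Phenyl in place of cyano gives a 1.6-fold higher number from compound 3 to compound 4 (0.20 log units; within the scatter), so these two groups cannot be told apart in this assay, and only methyl and phenyl separate, which shows that this place can affect clearance even though a single swap may not reveal it. No measured evidence bears on the reason for this difference.

On these data alone, it remains open whether the aromatic ring itself matters or whether any group with more carbon atoms would do the same, a question that a cyclohexyl ring or a longer chain such as butyl at this place could help to answer. It is also unclear how a carboxylic acid or a second amine at the end of the chain would fit into this small series.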